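Tert-butyl for methyl: what to expect of compound 4

This account rests on a few compounds, and the source may have more. Where it says the series, first, only, none or still open, it means among the compounds named here.

Compound 1 `Cc1ccccc1NC(=O)N[C@H](C)c1ccccc1` gives 100% in an ADME assay on the whole organism with Oryza sativa as the target, tested at 1 uM; on this read-out higher numbers stand for a weaker effect at the one concentration tested and lower numbers for a stronger effect. Compound 2 `Cc1ccccc1NC(=O)N[C@@H](C)c1ccccc1` gives 99%. Compound 3 `CC(C)c1ccc(NC(=O)N[C@H](C)c2ccccc2)cc1` gives 79%.

Among these three, compound 1 stands highest, with compound 2 nearest and compound 3 furthest, its number beyond the scatter of compound 1. Among the measured compounds shown here, the only measured step that changes one thing at a time is a number 1 percentage points lower from compound 1 to compound 2 (within the scatter), a step that is explained by the fact that compounds 1 and 2 differ only in the configuration as drawn as a change of drawn configuration alone. Compound 3 differs from compound 1 in more than one place, so its lower number can only be noted, not traced to a single change.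

Compound 4 `C[C@@H](NC(=O)Nc1ccccc1C(C)(C)C)c1ccccc1` is the unmeasured one. The change from compound 1 is this: tert-butyl in place of methyl on an aromatic carbon. For the measured compounds named here, no measured step shares this change, and the one step on record touches neither the group nor its place. Compound 4 is therefore expected to sit near compound 1 in this assay, its estimated step being a number 10 percentage points lower from compound 1 to compound 4 (within the scatter). The estimate for compound 4 is 90%, between 70% and 100%.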

Compound 4, a percentage reported as activity, at one concentration (the size of the read-out at that concentration, not a potency): 95%
For compound 4 the middle estimate is 5 percentage points below the measured one, and the stated range covers the measured number.
By their numbers in this assay, from the lowest: compound 3; then compounds 4, 2 and 1 (each within the scatter of the next).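

At this place, on an aromatic carbon of a six-membered aromatic ring of carbon only, tert-butyl in place of methyl gives a number 5 percentage points lower from compound 1 to compound 4 (within the scatter) in this assay. Among the compounds shown here, the position therefore takes a group of 4 heavy atoms instead of 1 without a step beyond the scatter, something the earlier compounds could not show, as their only single-place step concerned drawn configuration. That configuration step does not bear on this change of group, so nothing on record accounts for the new step.

Going by these compounds, whether an amine, a carboxylic acid or a longer chain at this place would also stay within the scatter of compound 1 remains open. Also open is what lies behind the lower number of compound 3, which no single change yet connects to the other compounds.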